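Replacing an Aromatic Amino Group with an Ethyl Ester

The source may hold more compounds than are shown below. What is called first, only, known or untested is meant among the compounds shown, and "the series" means these compounds.

Measured compounds:
compound 1, `CCCCc1c(F)c(N)c2c(=O)cc(-c3ccc(N)c(F)c3)oc2c1F`: 8800 nM
compound 2, `Nc1ccc(-c2cc(=O)c3c(N)c(F)c(N)c(F)c3o2)cc1F`: 7.7 nM

The two measured compounds share one core and differ in a single group on an aromatic carbon. In a functional assay on MCF7 cells (Homo sapiens) for cytotoxicity, read by neutral red uptake, with a stated time of 3 days (a lower number here means a stronger inhibitor, a higher number a weaker inhibitor), compound 1 gives 8800 nM and compound 2 gives 7.7 nM. The step between them is a 1100-fold lower number from compound 1 to compound 2 (3.06 log units; beyond the scatter). For the measured compounds named here, on the two numbers available, compound 2 stands lowest; its only neighbour is compound 1, whose number lies far higher, well beyond the scatter.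

Compound 3 is `CCOC(=O)c1c(F)c(N)c2c(=O)cc(-c3ccc(N)c(F)c3)oc2c1F`. Relative to compound 2 the change is ethoxycarbonyl in place of amino on an aromatic carbon. Going by the values given here, only one measured step bears on it: a 1100-fold lower number from compound 1 to compound 2 (3.06 log units; beyond the scatter), which shows that the amino group at this carbon goes with a very much lower number than butyl does. Compound 3 also gives up that amino group, though what enters is ethoxycarbonyl rather than butyl, so the size of the effect is uncertain. A large rise is therefore expected in this assay; the expected step is a 260-fold higher number from compound 2 to compound 3 (2.41 log units; beyond the scatter). For compound 3 the estimate is 2000 nM, within a range from 200 nM to 20000 nM.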

Compound 3, half-maximal inhibitory concentration: 1400 nM
Compound 3: middle estimate off by 1.4-fold (0.15 log units), on the high side; low and high end bracket the measured number.
By their numbers in this assay, from the lowest: compound 2; then compound 3; then compound 1.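

In this assay the step of a 180-fold higher number from compound 2 to compound 3 (2.26 log units; beyond the scatter) shows that ethoxycarbonyl does not take the place of the amino group at this carbon, so the large loss seen earlier with butyl is not confined to that one group. The step of a 6.3-fold lower number from compound 1 to compound 3 (0.80 log units; beyond the scatter) adds something the first pair could not show: the groups that replace the amino group are not all equal, since ethoxycarbonyl gives a modestly lower number than butyl, though it remains far from compound 2 and the amino compound stays lowest of the three. No measurement available here accounts for these differences between the groups.

The three compounds leave open whether a close relative of the amino group, such as a methylamino or hydroxyl group, would keep a number near that of compound 2, or whether only the amino group itself does. They also leave open whether a carboxylic acid, a primary amide or a smaller methyl ester at this carbon would fall nearer to compound 2 or nearer to compound 3.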